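The source may report more compounds than this note shows. Statements on the series, on what has been measured and on what is new or still open speak of the compounds shown alone.

Measured in a functional assay on MCF7 cells (Homo sapiens) for inhibition (a lower number here means a stronger inhibitor, a higher number a weaker inhibitor), so far
compound 1 `CCCCCCCC[C@@]1(C)SC(=O)C=C1OCC(=O)O` gives 13.8 ug/mL
compound 2 `CCCCCCCC[C@@]1(C)SC(=O)C=C1OC(=O)CC` gives 22.6 ug/mL
compound 3 `CCCCCCCC[C@@]1(C)SC(=O)C=C1OC(=O)OC` gives 10.7 ug/mL

Among the compounds with values here, compound 3 sits within the scatter of compound 1, and its one step beyond the scatter is a 2.1-fold lower number from compound 2 to compound 3 (0.32 log units; beyond the scatter) in this small set. Compound 4 `CCCCCCCC[C@@]1(C)SC(=O)C=C1OC(=O)OCC` differs from compound 3 by methyl in place of hydrogen on a saturated chain carbon bound to an oxygen next to a carbonyl group and the change reads methyl in place of hydrogen on a saturated chain carbon bound to an oxygen next to a carbonyl group, so methoxycarbonyl becomes ethoxycarbonyl. Within the data shown here, no measured step makes this exact change. The closest evidence is the modest 2.1-fold lower number from compound 2 to compound 3 (0.32 log units; beyond the scatter) for methoxy in place of ethyl on a carbonyl carbon, together with a 1.3-fold lower number from compound 1 to compound 3 (0.11 log units; within the scatter) for methoxycarbonyl in place of carboxymethyl. Nothing beyond the scatter is therefore expected, and the estimated shift is a 1.1-fold higher number from compound 3 to compound 4 (0.05 log units; within the scatter) in this assay readings. For compound 4 the expected value is 12 ug/mL with an estimated range between 6.5 ug/mL and 22 ug/mL in this assay readings.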

Compound 4, half-maximal inhibitory concentration: 14.5 ug/mL
Estimate against measurement, compound 4: 1.2-fold (0.08 log units) below, within the range that was stated.
By their numbers in this assay, from the lowest: compounds 3, 1, 4 and 2 (each within the scatter of the next, the first and the last beyond it).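

In this assay, the methyl added to the saturated chain carbon gives only a small step (a 1.4-fold higher number from compound 3 to compound 4 (0.13 log units; within the scatter)), so methoxycarbonyl and ethoxycarbonyl cannot be told apart at this position. Ethoxy in place of ethyl on the carbonyl carbon also stays within the scatter (a 1.6-fold lower number from compound 2 to compound 4 (0.19 log units; within the scatter)), unlike methoxy in the same place (a 2.1-fold lower number from compound 2 to compound 3 (0.32 log units; beyond the scatter)), while ethoxycarbonyl and carboxymethyl cannot be separated (a 1.1-fold higher number from compound 1 to compound 4 (0.02 log units; within the scatter)). Nothing available bears on the reason for these small steps. Still open, from the compounds shown here alone, is whether a longer chain on this oxygen, or an amine in place of the ethoxy, would move the number beyond the scatter.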